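The compounds below may be only part of what the source reports. "The series", "measured", "known", "first", "only" and "open" are said of these compounds alone.

In an ADME assay on BJ cells (Homo sapiens) for cytotoxicity, with a stated time of 72 h (on this read-out higher numbers stand for an effect only at larger amounts of compound and lower numbers for an effect already at smaller amounts), compound 1 `Cc1nn(-c2ccccc2)c2nc(-c3ccc(C(F)(F)F)cc3)c(C#N)c(-c3ccccc3O)c12` gives 22900 nM. Compound 2 `Cc1nn(-c2ccccc2)c2nc(-c3ccc(Cl)cc3)c(C#N)c(-c3ccccc3O)c12` gives only a limit, > 20000 nM, and not a number. Among the compounds with values here, the one measured step, a step that the limit leaves unreadable from compound 1 to compound 2, puts chloro in place of trifluoromethyl on an aromatic carbon, and it has no readable size. The data also show (the limit of > 20000 nM in this assay, at which 1 of the 2 values shown sits), so a further result could end at that limit too.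

Compound 3 `Cc1nn(-c2ccccc2)c2nc(-c3ccc4c(c3)OCCO4)c(C#N)c(-c3ccccc3O)c12` brings the next change, 2,3-dihydro-1,4-benzodioxin-6-yl in place of 4-chlorophenyl on an aromatic carbon, next to the ring nitrogen. Within the data shown here, with compound 1 at 22900 nM as the only readable number, no step beyond the usual scatter is expected in this assay, and no direction can be favoured. The estimated step is a step that the limit leaves unreadable from compound 2 to compound 3. Compound 3 is expected at about 25000 nM, with an estimated range from 14000 nM to 45000 nM.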

Compound 3, half-maximal effective concentration: > 20000 nM
Compound 3: no number, only a limit; the forecaster's own chance of this, stated with the estimate: 65%; the middle value does not contradict the limit.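

In this assay compound 3 gives > 20000 nM, which is a limit and not a number. Within the data shown here, no step from compound 1 or compound 2 to compound 3 can be read. The compounds shown leave open how the three groups at this one place truly compare, with most values resting on a limit: the limit of > 20000 nM in this assay, at which 2 of the 3 values shown sit.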